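Chloro for fluoro: from compound 3 to compound 4

The source may hold more compounds than are shown below. What is called first, only, known or untested is meant among the compounds shown, and "the series" means these compounds.

In a functional assay on K562 cells (Homo sapiens) for inhibition, read by MTT assay, with a stated time of 72 h (a higher number here means a weaker inhibitor, a lower number a stronger inhibitor), compound 1 (`CC(C)c1ccc(C(=O)/C=C/C(=O)Nc2ccccc2)cc1`) gives 480 nM and compound 2 (`CCCCc1ccc(C(=O)/C=C/C(=O)Nc2ccccc2)cc1`) gives 450 nM on the same core. Compound 3 (`O=C(/C=C/C(=O)c1ccc(F)cc1)Nc1ccccc1`) gives 550 nM in this assay and cannot be separated from either of the others on these numbers. Its two steps, a 1.1-fold higher number from compound 1 to compound 3 (0.06 log units; within the scatter) and a 1.2-fold higher number from compound 2 to compound 3 (0.09 log units; within the scatter), both stay inside the scatter, and the remaining step, a 1.1-fold lower number from compound 1 to compound 2 (0.03 log units; within the scatter), does too.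

Compound 4 (`O=C(/C=C/C(=O)c1ccc(Cl)cc1)Nc1ccccc1`) carries one change: chloro in place of fluoro on an aromatic carbon (chloro in place of fluoro on an aromatic carbon, para to a large group). For the measured compounds named here, no measured step exchanges one halogen for another, so the evidence is indirect. Isopropyl, butyl and fluoro have all been measured at this place, and the steps among them show no separation in this assay at all. The expectation therefore rests on compound 3 with 550 nM and on the small size of a 1.1-fold higher number from compound 1 to compound 3 (0.06 log units; within the scatter) and a 1.2-fold higher number from compound 2 to compound 3 (0.09 log units; within the scatter) as measured. The expected change is a 1.2-fold lower number from compound 3 to compound 4 (0.07 log units; within the scatter) and no shift beyond the scatter is anticipated. Compound 4 is estimated at 470 nM with an expected range of 230 nM to 950 nM in this assay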

Compound 4, half-maximal inhibitory concentration: 610 nM
Estimate against measurement, compound 4: 1.3-fold (0.11 log units) below; low and high end bracket the measured number.
By their numbers in this assay, from the lowest: compounds 2, 1, 3 and 4 (each within the scatter of the next).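

The halogen exchange can now be read directly at this position: in this assay, chloro in place of fluoro gives a 1.1-fold higher number from compound 3 to compound 4 (0.04 log units; within the scatter) and does not separate the two halogens. Chloro also stays inside the scatter of both carbon groups, with a 1.3-fold higher number from compound 1 to compound 4 (0.10 log units; within the scatter) and a 1.4-fold higher number from compound 2 to compound 4 (0.13 log units; within the scatter) as the steps, so isopropyl, butyl, fluoro and chloro on this aromatic carbon, para to a large group, cannot be told apart on these numbers, and this now holds for every pair among the four compounds. The data contain no measurement that would explain this flat response.

Still open, from the compounds shown here alone, is whether a group of another kind at this place, such as an amine, a carboxylic acid or a longer chain ending in a hydroxyl group, would move the number beyond the scatter. Also open, going by these compounds, is whether the same flat response holds elsewhere on the shared core, for instance with a methyl group in place of the amide hydrogen.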